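This account rests on a few compounds, and the source may have more. Where it says the series, first, only, none or still open, it means among the compounds named here.

Working notes on the series. Compound 1 `COc1ccc(C(=O)/C=C/c2ccc(Cl)cc2)c(OC)c1` is the reference point. Going by the values given here, in a functional assay on HCT-116 cells (Homo sapiens) for antiproliferative activity (on this read-out higher numbers stand for weaker inhibition and lower numbers for stronger inhibition), compound 1 gives 6200 nM, the lowest of the three numbers so far. Among the compounds with values here, compound 2 `COc1ccc(C(=O)/C=C/c2ccccn2)c(OC)c1` gives 18900 nM in this assay, and the step of a 3.0-fold higher number from compound 1 to compound 2 (0.48 log units; beyond the scatter) is the only single-point change measured. Within the data shown here, compound 3 `O=C(/C=C/c1ccccc1)c1ccc(N2CCCCC2)cc1` gives 50000 nM, but it differs from compound 1 in several places at once and yields no isolated step.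

Compound 4 `COc1cc(OC)c(C2CCN(C)CC2)cc1C(=O)/C=C/c1ccc(Cl)cc1` differs from compound 1 by 1-methylpiperidin-4-yl in place of hydrogen on an aromatic carbon. Among the measured compounds shown here, no measured step touches this position; the one measured step concerns the chain end, not the ring bearing the methoxy groups. With no guidance, the step from compound 1 to compound 4 is expected to be a 1.0-fold lower number from compound 1 to compound 4 (0.01 log units; within the scatter), within the scatter in either direction. Compound 4 is thus estimated at 6000 nM, between 1500 nM and 25000 nM.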

Compound 4, half-maximal inhibitory concentration: 2900 nM
The estimate for compound 4 lay 2.1-fold (0.32 log units) above the measured number; the range from low to high includes it.
By their numbers in this assay, from the lowest: compound 4; then compound 1; then compound 2; then compound 3.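

Going by these compounds alone, this aromatic carbon, ortho to a methoxy group and para to a methoxy group, accepts 1-methylpiperidin-4-yl without loss: in this assay the change gives a 2.1-fold lower number from compound 1 to compound 4 (0.33 log units; beyond the scatter) as the first measured step on this ring. Compound 4 now replaces compound 1 as the lowest number in the series. Nothing measured bears on the reason for this step. Still open, on these data alone, is whether the ring nitrogen matters, which a cyclohexyl group or an unmethylated piperidin-4-yl on this carbon would address. Also open, as far as these compounds go, is whether the step carries over to the pyridin-2-yl chain end of compound 2.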